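Replacing the Octyl Ether Chain with a Heteroaromatic Ring

The compounds below may be only part of what the source reports. "The series", "measured", "known", "first", "only" and "open" are said of these compounds alone.

The measured compounds and their values in a functional assay on HEK293 cells for agonist activity at G-protein coupled receptor 39 (Homo sapiens), read by scintillation proximity assay and inositol phosphate accumulation, with a stated time of 75 min, in the presence of a further agent that is not named here; on this read-out higher numbers stand for an effect only at larger amounts of compound and lower numbers for an effect already at smaller amounts:
compound 1 `Cc1nn(-c2ncnc3nc[nH]c23)c2c1C(OC1CCCC1)CC(=O)N2` gives 2 nM
compound 2 `Cc1nn(-c2ncnc3nc[nH]c23)c2c1C(C(=O)NCc1ccc(F)cc1)CC(=O)N2` gives 4 nM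
compound 3 `CCCCCCCCOC1CC(=O)Nc2c1c(C)nn2-c1ncnc2nc[nH]c12` gives 8 nM

Compound 3 stands highest of the three numbers. Its nearest neighbour is compound 2, which lies within the scatter of it, while compound 1 is furthest from it, beyond the scatter. Among the measured compounds shown here, the one measured step that touches the ether position is a 4.0-fold higher number from compound 1 to compound 3 (0.60 log units; beyond the scatter), where octyl replaced cyclopentyl on the oxygen.

Compound 4 `Cc1noc(C)c1COC1CC(=O)Nc2c1c(C)nn2-c1ncnc2nc[nH]c12` is the next compound, not yet measured. Its change from compound 3 is 3,5-dimethyl-1,2-oxazol-4-yl in place of heptyl on a saturated chain carbon bound to an oxygen on a saturated carbon. For the measured compounds named here, the only step bearing on it is the one from compound 1 to compound 3, which showed that a ring on that oxygen gave a lower number than the long chain. Going by the values given here, no measured compound carries an aromatic ring at this place, so the expectation is a modest step back toward lower numbers, or no step beyond the scatter. Compound 4 is therefore expected to give 5 nM, in the range 1.5 nM to 16 nM. That amounts to an expected 1.6-fold lower number from compound 3 to compound 4 (0.20 log units; within the scatter).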

Compound 4, half-maximal effective concentration: 5 nM
Compound 4: middle estimate and measured number agree at the digits printed, and the stated range covers the measured number.
By their numbers in this assay, from the lowest: compounds 1, 2, 4 and 3 (each within the scatter of the next, the first and the last beyond it).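

In this assay, the ether position takes the aromatic 3,5-dimethyl-1,2-oxazol-4-yl group in place of heptyl with a 1.6-fold lower number from compound 3 to compound 4 (0.20 log units; within the scatter), so a five-membered aromatic ring with two hetero atoms is not separated from the saturated chain on this read-out. Set against the cyclopentyl ether, the (3,5-dimethyl-1,2-oxazol-4-yl)methyl group gives a 2.5-fold higher number from compound 1 to compound 4 (0.40 log units; beyond the scatter), and so compound 1 stands apart from both the chain and this ring. Nothing available explains either step.

The compounds shown leave open whether the two methyl groups on the new ring contribute, as no unsubstituted 1,2-oxazole appears among them. They also leave open how a benzyl group, a pyridine or a tertiary amine would read at this oxygen.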